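The compounds below may be only part of what the source reports. "The series", "measured", "known", "first", "only" and "open" are said of these compounds alone.

In an ADME assay on THP-1 cells (Homo sapiens) for cytotoxicity, read by flow cytometry and propidium iodide staining, with a stated time of 72 h (on this read-out higher numbers stand for weaker inhibition and lower numbers for stronger inhibition), compound 3 (`COc1c(-c2cccc(C(F)(F)F)c2)oc2ccc(NC(C)=O)cc2c1=O`) gives 52000 nM. That puts it at the high end of the series, level within the scatter with compound 1 (`CC(=O)Nc1ccc2oc(-c3cccc(C(F)(F)F)c3)cc(=O)c2c1`) at 50000 nM, while compound 2 (`CC(=O)Nc1ccc2oc(-c3cccc(C(F)(F)F)c3)c(O)c(=O)c2c1`) gives 1000 nM. The steps measured so far involve only the hydroxy and methoxy groups: a 50-fold lower number from compound 1 to compound 2 (1.70 log units; beyond the scatter) for hydroxy in place of hydrogen, a 1.0-fold higher number from compound 1 to compound 3 (0.02 log units; within the scatter) for methoxy in place of hydrogen, and a 52-fold higher number from compound 2 to compound 3 (1.72 log units; beyond the scatter) for methyl in place of hydrogen on the oxygen. Compound 4 (`COc1c(-c2cccc(C(F)(F)F)c2)oc2ccc(N)cc2c1=O`) differs elsewhere, with hydrogen in place of acetyl on a nitrogen on an aromatic ring, or acetamido to amino: hydrogen in place of acetyl on a nitrogen on an aromatic ring. Going by the values given here, no measured step touches this group, so those steps show only that large changes can occur. The data therefore give no firm direction, and no step beyond the scatter is the best expectation in this assay, with a slight lean towards a lower number. The estimated change is a 1.7-fold lower number from compound 3 to compound 4 (0.24 log units; within the scatter). For compound 4 the expected value is 30000 nM, with an estimated range from 7000 nM to 80000 nM.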

Compound 4, half-maximal inhibitory concentration: 33000 nM
Compound 4: middle estimate off by 1.1-fold (0.04 log units), on the low side, and the stated range covers the measured number.
By their numbers in this assay, from the lowest: compound 2; then compounds 4, 1 and 3 (each within the scatter of the next).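

In this assay the swap of acetyl for hydrogen on the nitrogen on the aromatic ring, acetamido to amino, gives a 1.6-fold lower number from compound 3 to compound 4 (0.20 log units; within the scatter) and so stays within the scatter. Going by these compounds alone, this is the first measured change at this position, and it shows that, with the methoxy group kept in place, the read-out does not register the loss of the acetyl group. No measured evidence accounts for this result.

As far as these compounds go, whether the same swap would also be this small with a hydroxy group in place of the methoxy group stays open, as compound 2, which carries that hydroxy group, gives 1000 nM and has no amino partner here. Also open, from the compounds shown here alone, is what a longer acyl chain, a methyl group or a sulfonamide on that nitrogen would give.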